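A few compounds are considered here, and "the series" means these few. Any claim that something is new, unique, unknown or untested is made for them only; others in the source may bear on it.

Of the compounds shown here, three built on one shared core have been measured in a functional assay on HCT-116 cells (Homo sapiens) for cytotoxicity, read by MTT assay, with a stated time of 72 h; a lower number here means a stronger inhibitor, a higher number a weaker inhibitor. Compound 1 `CN1CCN(CCCCCCn2c3c(c4ccccc42)C(=O)c2c[n+]([O-])c4ccccc4c2C3=O)CC1` gives 2900 nM. Compound 2 `O=C1c2c[n+]([O-])c3ccccc3c2C(=O)c2c1c1ccccc1n2CCCCN1CCNCC1` gives 700 nM. Compound 3 `O=C1c2c[n+]([O-])c3ccccc3c2C(=O)c2c1c1ccccc1n2CCN1CCCC1` gives 270 nM. Compound 3 thus stands lowest of the three: the steps run a 4.1-fold lower number from compound 1 to compound 2 (0.62 log units; beyond the scatter), an 11-fold lower number from compound 1 to compound 3 (1.03 log units; beyond the scatter) and a 2.6-fold lower number from compound 2 to compound 3 (0.41 log units; beyond the scatter), each beyond the scatter, so compound 3 is the most potent of the measured set.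

Compound 4 `O=C1c2c[n+]([O-])c3ccccc3c2C(=O)c2c1c1ccccc1n2CCCN1CCC(O)CC1` is the next step from compound 3: (4-hydroxypiperidin-1-yl)methyl in place of pyrrolidin-1-yl on a saturated chain carbon, two bonds along the chain from an aromatic nitrogen. All three measured steps bear on it, since each exchanges the group sitting on the chain that runs from an aromatic nitrogen, and together they show the number falling as that chain was cut back, from compound 1 through compound 2 to compound 3. The change to compound 4 runs the other way, building the chain out again, though not as far as in compound 2. On that basis a modest rise in the number is expected rather than a fall, smaller than the step of a 2.6-fold lower number from compound 2 to compound 3 (0.41 log units; beyond the scatter) reversed. Compound 4 is therefore estimated at 450 nM, with a range from 200 nM to 1100 nM, which would be a step of a 1.7-fold higher number from compound 3 to compound 4 (0.22 log units; within the scatter).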

Compound 4, half-maximal inhibitory concentration: 190 nM
For compound 4 the middle estimate is 2.4-fold (0.37 log units) above the measured one; measured number outside the range, below it.
By their numbers in this assay, from the lowest: compounds 4 and 3 (each within the scatter of the next); then compound 2; then compound 1.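

In this assay, putting 3-(4-hydroxypiperidin-1-yl)propyl in place of 2-(pyrrolidin-1-yl)ethyl gives a 1.4-fold lower number from compound 3 to compound 4 (0.15 log units; within the scatter), so this position accepts the larger ring with its hydroxyl, and compound 3 and compound 4 cannot be told apart. The earlier fall in the number as the chain was cut back does not extend to compound 4, which goes against it: its chain is longer than that of compound 3, yet the data show a 3.7-fold lower number from compound 2 to compound 4 (0.57 log units; beyond the scatter) and a 15-fold lower number from compound 1 to compound 4 (1.18 log units; beyond the scatter), so chain length alone does not order these four compounds. Nothing available here accounts for this result.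

The compounds shown leave open how much of each step belongs to the chain and how much to the ring at its end, as both change together in every pair; a 3-(pyrrolidin-1-yl)propyl or a 2-(4-hydroxypiperidin-1-yl)ethyl group would separate the two. They also leave open what the hydroxyl itself contributes, which a plain piperidine on the same propyl chain would test.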